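The compounds below may be only part of what the source reports. "The series", "measured", "known", "first", "only" and "open" are said of these compounds alone.

In a functional assay on Raji cells (Homo sapiens) for antiproliferative activity, read by CCK-8 assay, with a stated time of 48 h (on this read-out lower numbers stand for stronger inhibition and higher numbers for weaker inhibition), compound 3 `C=CC(=O)Nc1cccc(-n2cnc3cnc(Nc4ccc(N5CCN(S(C)(=O)=O)CC5)cc4)nc32)c1` returns no number, only a limit of > 40000 nM. It therefore stands at the limit of > 40000 nM in this assay, at which 1 of the 3 values shown sits. Compound 1 `C=CC(=O)Nc1cccc(-n2cnc3cnc(Nc4ccc(N5CCN(C)CC5)cc4)nc32)c1` gives 7550 nM, and compound 2 `C=CC(=O)Nc1cccc(-n2cnc3cnc(Nc4ccc(N5CCN(S(C)(=O)=O)C(C)C5)cc4)nc32)c1` gives 31700 nM. Compound 4 `C=CC(=O)Nc1cccc(-n2cnc3cnc(Nc4ccc(N5CCN(C(C)=O)C(C)C5)cc4)nc32)c1` carries 4-acetyl-3-methylpiperazin-1-yl in place of 4-(methylsulfonyl)piperazin-1-yl on an aromatic carbon.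

Among the measured compounds shown here, three measured steps bear on this change. The ring methyl alone gives an at least 1.2-fold higher number from compound 2 to compound 3 (0.10 log units; that floor lies within the scatter), whose floor lies within the scatter. The two steps away from the 4-methylpiperazin-1-yl group are larger: a 4.2-fold higher number from compound 1 to compound 2 (0.62 log units; beyond the scatter) and an at least 5.2-fold higher number from compound 1 to compound 3 (0.72 log units; beyond the scatter). For the measured compounds named here, no measured step exchanges methylsulfonyl for acetyl, so that part of the change is untested. A modest move to a lower number is expected, since compound 2 at 31700 nM already gives a number and compound 1 at 7550 nM marks the lower side of this small set. The expected step is an at least 2.0-fold lower number from compound 3 to compound 4 (0.30 log units; that floor lies within the scatter). The estimate for compound 4 is 20000 nM, with an expected range from 7500 nM to 40000 nM.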

Compound 4, half-maximal inhibitory concentration: 24200 nM
The estimate for compound 4 lay 1.2-fold (0.08 log units) below the measured number; the measured number falls inside the stated range.
By their numbers in this assay, from the lowest: compound 1; then compounds 4 and 2 (each within the scatter of the next). At a limit, above all of these: compound 3.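

In this assay, the exchange of methylsulfonyl for acetyl on the ring amine nitrogen, with the ring methyl kept, gives a 1.3-fold lower number from compound 2 to compound 4 (0.12 log units; within the scatter), so this change does not separate the two groups at this position. Against the 4-methylpiperazin-1-yl group of compound 1 there is a 3.2-fold higher number from compound 1 to compound 4 (0.51 log units; beyond the scatter), which shows that the higher number seen with the methylsulfonyl compounds also holds for an acetyl group on that nitrogen. The remaining step, an at least 1.6-fold lower number from compound 3 to compound 4 (0.21 log units; that floor lies within the scatter), gives only a floor, and compound 3 itself has a limit and not a number: the limit of > 40000 nM in this assay, at which 1 of the 4 values shown sits.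

As far as these compounds go, the ring methyl and the acetyl appear only together, so the effect of acetyl on the piperazine without that methyl remains open. Also open, from the compounds shown here alone, is where a free ring amine or a longer acyl chain on that nitrogen would stand relative to compound 1.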